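A few compounds are considered here, and "the series" means these few. Any claim that something is new, unique, unknown or untested is made for them only; others in the source may bear on it.

Going by the values given here, in a physicochemical assay for lipophilicity (a higher number here means a more lipophilic compound, a lower number a more polar compound), compound 2 `CNCC(=O)Nc1ccc(-c2nc(C(C)(C)S(C)(=O)=O)cc([C@]34CCOC[C@H]3C4)n2)cc1` reads 4.3, the higher of the two values so far and beyond the scatter from compound 1 `CNCC(=O)Nc1ccc(-c2nc(CS(C)(=O)=O)cc([C@@]34CCOC[C@@H]3C4)n2)cc1`, which reads 3.1. Compound 3 `CNCC(=O)Nc1ccc(-c2nc(CS(C)(=O)=O)cc([C@]34CCOC[C@H]3C4)n2)cc1` comes from compound 2 by one change: (methylsulfonyl)methyl in place of 1-methyl-1-(methylsulfonyl)ethyl on an aromatic carbon. Among the compounds with values here, no measured pair isolates this change, so the expectation rests on compound 1, which carries the same (methylsulfonyl)methyl group and reads 3.1. A fall beyond the scatter is expected in this assay, with an estimated a number 1.20 log units lower from compound 2 to compound 3 (beyond the scatter). For compound 3 the estimated value is 3.1, with an expected range of 2.8 to 3.4.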

Compound 3, partition coefficient: 3.1
For compound 3 middle estimate and measured number coincide at the digits printed; measured number inside the range.
By their numbers in this assay, from the lowest: compounds 1 and 3 (each within the scatter of the next); then compound 2.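

With the two groups now compared directly on this aromatic carbon, in this assay (methylsulfonyl)methyl in place of 1-methyl-1-(methylsulfonyl)ethyl gives a number 1.20 log units lower from compound 2 to compound 3 (beyond the scatter). Inverting both stereocentres with (methylsulfonyl)methyl in place gives no change at the digits printed from compound 1 to compound 3 (within the scatter). That second comparison involves stereochemistry alone: the fact that compounds 1 and 3 differ only in the configuration as drawn

From the compounds shown here alone, whether an amine, a carboxylic acid or a longer chain at this position would read differently in this assay remains open. Also open, going by these compounds, is whether inverting the configuration has any effect on this read-out with 1-methyl-1-(methylsulfonyl)ethyl in place.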